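Methoxy additions on a hydroxyphenyl urea series

The source may hold more compounds than are shown below. What is called first, only, known or untested is meant among the compounds shown, and "the series" means these compounds.

Measured so far:
- compound 1 `COc1ccc2c(c1)CN(C(=O)N(C)C)CC2c1cccc(O)c1`: 402 nM
- compound 2 `COc1cccc2c1CN(C(=O)N(C)C)CC2c1cccc(O)c1`: 332 nM

Both compounds were tested in a functional assay on A2780 cells (Homo sapiens) for antiproliferative activity; on this read-out lower numbers stand for stronger inhibition and higher numbers for weaker inhibition. Among the measured compounds shown here, compound 1 and compound 2 differ only in where the single methoxy group sits on the shared core. For the measured compounds named here, compound 2 gives 332 nM, and this value lies within the scatter of the one for compound 1 . Going by the values given here, with only these two compounds measured, no single-site step is available to calibrate the next change.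

The next compound is compound 3 `COc1ccc2c(c1OC)CN(C(=O)N(C)C)CC2c1cccc(O)c1`. It follows from compound 2 by one change: methoxy in place of hydrogen on an aromatic carbon. Among the compounds with values here, no measured step shows what adding a methoxy group does in this assay, so the expectation is weakly supported. Within the data shown here, the only evidence is that moving the methoxy group left the values of compound 1 and compound 2 within the scatter. No change beyond the scatter is expected, in either direction.

The estimated 1.0-fold lower number from compound 2 to compound 3 (0.02 log units; within the scatter) is therefore expected to be small. For compound 3 the expected value is 320 nM, with an estimated range from 110 nM to 900 nM.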

Compound 3, half-maximal inhibitory concentration: 2920 nM
Beside the measured number, compound 3's estimate is 9.1-fold (0.96 log units) below it; the whole stated range lies below it.
By their numbers in this assay, from the lowest: compounds 2 and 1 (each within the scatter of the next); then compound 3.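

Compound 3 carries the methoxy groups of both compound 1 and compound 2 on the shared core, and in this assay the combination behaves differently from either single placement: an 8.8-fold higher number from compound 2 to compound 3 (0.94 log units; beyond the scatter) and a 7.3-fold higher number from compound 1 to compound 3 (0.86 log units; beyond the scatter). Both steps lie beyond the scatter and point towards weaker inhibition, so the aromatic carbon that takes the new methoxy group, ortho to a methoxy group, is not indifferent to substitution in this setting, and the earlier match between the two single-methoxy compounds gave no sign of this. Nothing available explains the loss of activity.

The compounds shown leave open whether the loss is specific to methoxy or would also follow from a smaller group such as fluorine or hydroxyl, or from a longer chain such as ethoxy, at the same carbon. They also leave open whether the effect holds in other dimethoxy arrangements on the core, or with the hydroxyl on the phenyl ring replaced by an amine.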